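This account rests on a few compounds, and the source may have more. Where it says the series, first, only, none or still open, it means among the compounds named here.

In a functional assay on the whole organism (strain Sprague-Dawley) for inhibition, with Rattus norvegicus as the target, with a stated time of 10 min (a lower number here means that less compound is needed, a higher number that more compound is needed for the effect), three compounds sharing one core have been measured. Compound 2 (`CCOC(=O)c1cnc(-c2ccccc2OCC)[nH]c1=O`) gives 2 mg/kg, the middle of the three numbers. Compound 1 (`CCOc1ccc(Cl)cc1-c1ncc(C(=O)O)c(=O)[nH]1`) gives 0.5 mg/kg, and compound 3 (`CCCOc1ccccc1-c1ncc(C(=O)OCC)c(=O)[nH]1`) gives 5 mg/kg. Compound 4 (`CCOC(=O)c1cnc(-c2cc(Cl)ccc2OCC)[nH]c1=O`) is compound 2 with a single change: chloro in place of hydrogen on an aromatic carbon, para to the ethoxy group.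

Among the compounds with values here, no measured step isolates this change. Within the data shown here, the only single-place step, a 2.5-fold higher number from compound 2 to compound 3 (0.40 log units; beyond the scatter), lengthens the ethoxy chain, so it shows only that one small edit on this core can move the number modestly. Compound 1 carries the same chloro and gives 0.5 mg/kg, but it also has a carboxylic acid where compound 2 has an ethyl ester, so its lower number cannot be credited to chloro alone. That gives a weak hint towards a lower number, and a modest step at most seems reasonable. The expected step in this assay is a 2.0-fold lower number from compound 2 to compound 4 (0.30 log units; within the scatter), with its direction uncertain. The estimate for compound 4 is 1 mg/kg, within an expected range from 0.3 mg/kg to 3 mg/kg.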

Compound 4, dose for 50% inhibition: 0.5 mg/kg
Estimate against measurement, compound 4: 2.0-fold (0.30 log units) above; the measured number falls inside the stated range.
By their numbers in this assay, from the lowest: compounds 1 and 4 (each within the scatter of the next); then compound 2; then compound 3.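

Within the data shown here, on the aromatic carbon para to the ethoxy group, chloro alone has a real effect in this assay: the change gives a 4.0-fold lower number from compound 2 to compound 4 (0.60 log units; beyond the scatter), which the earlier compounds could only hint at. Compound 1 had carried chloro together with a carboxylic acid, but now the ethyl can be read by itself, and swapping the acid hydrogen for ethyl gives no change at the digits printed from compound 1 to compound 4 (within the scatter), so with chloro in place this edit shows no readable effect. Nothing available here explains why chloro lowers the number.

Going by these compounds, whether fluoro, bromo, methyl or an amine on the same carbon would lower the number as well remains open. So does whether chloro would give a similar step on the propoxy chain of compound 3.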